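The compounds below may be only part of what the source reports. "The series", "measured", "known", "first", "only" and "open" are said of these compounds alone.

Measured so far in a functional assay on HEL cells (Homo sapiens); a lower number here means that less compound is tolerated, a higher number that more compound is tolerated:
Compound 1 `O=c1nc2occc2cn1COCCO` gives > 200000 nM, which is a limit of this assay.
Compound 2 `CCCCCc1cc2cn(COCCO)c(=O)nc2o1` gives > 200000 nM, again a limit.
Compound 3 `OCCOCn1cc2ccnc-2nc1O` gives > 200000 nM, also a limit.

All three values sit at one limit: the limit of > 200000 nM in this assay, at which 3 of the 3 values shown sit. Compound 2 differs from compound 1 by pentyl in place of hydrogen on an aromatic carbon, and the step that the two limits leave unreadable from compound 1 to compound 2. How the core of compound 3 differs from the core of compound 1 is not broken down here.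

Compound 4 `CCCCCc1cc2cn(COCCO)c(O)nc-2n1` is not yet measured; it differs from compound 3 by pentyl in place of hydrogen on an aromatic carbon. This is the same kind of change as from compound 1 to compound 2, but not the same: there the ring is a five-membered aromatic ring with 1 oxygen, next to the ring oxygen, whereas here it is a five-membered aromatic ring with 1 nitrogen, next to the ring nitrogen.

Going by the values given here, the only reading of this change so far is unreadable, because both of its compounds sit at the limit of > 200000 nM in this assay, at which 3 of the 3 values shown sit. For compound 4 the expected step in this assay is therefore a step that the limit leaves unreadable from compound 3 to compound 4. Compound 4 is estimated at 300000 nM, between 150000 nM and 1000000 nM, most likely reported again only as a limit.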

Compound 4, half-maximal cytotoxic concentration: > 200000 nM
Compound 4 gave a limit, no number; the forecaster's own chance of this, stated with the estimate: 85%; the middle value is on the limit's open side.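

The step from compound 3 to compound 4 cannot be read, because both compounds sit at a limit: the limit of > 200000 nM in this assay, at which 4 of the 4 values shown sit.

The compounds shown leave open how far any of them lies past that limit in this assay and whether pentyl changes the value on either core.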